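A Chloro Swap in a Flat Series

The source may report more compounds than this note shows. Statements on the series, on what has been measured and on what is new or still open speak of the compounds shown alone.

In a functional assay on QGY-7703 cells (Homo sapiens) for cytotoxicity, read by MTT assay, with a stated time of 24 h (on this read-out lower numbers stand for stronger inhibition and higher numbers for weaker inhibition), compound 1 `O=C1/C(=C/c2ccncc2)CN(S(=O)(=O)c2ccccc2)C/C1=C\c1ccccc1F` gives 8400 nM, compound 2 `O=C1/C(=C/c2ccncc2)CN(S(=O)(=O)c2ccc([N+](=O)[O-])cc2)C/C1=C\c1ccccc1F` gives 8800 nM and compound 3 `O=C1/C(=C/c2ccncc2)CN(S(=O)(=O)c2ccc(F)cc2)C/C1=C\c1ccccc1F` gives 9100 nM. Compound 3 therefore stands level with the other two, all three lying within the scatter of one another. Compound 4 `O=C1/C(=C/c2ccncc2)CN(S(=O)(=O)c2ccc(Cl)cc2)C/C1=C\c1ccccc1F` has not yet been measured. It differs from compound 3 by one change, chloro in place of fluoro on an aromatic carbon, para to a large group.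

Among the measured compounds shown here, three measured steps bear on this place. They are a 1.0-fold higher number from compound 1 to compound 2 (0.02 log units; within the scatter), a 1.1-fold higher number from compound 1 to compound 3 (0.03 log units; within the scatter) and a 1.0-fold higher number from compound 2 to compound 3 (0.01 log units; within the scatter), and each is small and within the scatter. Hydrogen, nitro and fluoro thus read alike here, so no step beyond the scatter is expected in this assay for the new chloro group. The expected step is a 1.0-fold lower number from compound 3 to compound 4 (0.01 log units; within the scatter), which would stay within the scatter. For compound 4 the estimated value is 8800 nM, with an expected range of 5800 nM to 13000 nM.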

Compound 4, half-maximal inhibitory concentration: 12500 nM
The estimate for compound 4 lay 1.4-fold (0.15 log units) below the measured number; the measured number falls inside the stated range.
By their numbers in this assay, from the lowest: compounds 1, 2, 3 and 4 (each within the scatter of the next).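

Chloro at this place joins the groups that read alike in this assay: the step is a 1.4-fold higher number from compound 3 to compound 4 (0.14 log units; within the scatter) against fluoro, a 1.4-fold higher number from compound 2 to compound 4 (0.15 log units; within the scatter) against nitro and a 1.5-fold higher number from compound 1 to compound 4 (0.17 log units; within the scatter) against hydrogen. These steps are larger than the earlier ones at this position, yet each still lies within the scatter. Hydrogen, nitro, fluoro and chloro on this aromatic carbon, para to a large group, therefore cannot be told apart in this assay, and no measurement shown offers an explanation for this flat reading.

As far as these compounds go, whether an amine, a carboxylic acid or a longer chain in this place would move the number beyond the scatter remains open. From the compounds shown here alone, it is also open whether changes elsewhere on the shared core would prove equally silent.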